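Methoxy in place of trifluoromethyl: working notes

The compounds below may be only part of what the source reports. "The series", "measured", "known", "first", "only" and "open" are said of these compounds alone.

Measured so far in a functional assay on B16 cells (Mus musculus) for inhibition; on this read-out higher numbers stand for weaker inhibition and lower numbers for stronger inhibition
compound 1 `Cc1ccccc1CNC(=O)/C=C/c1ccc(O)c(O)c1` gives 20000 nM
compound 2 `O=C(/C=C/c1ccc(O)c(O)c1)NCc1ccccc1C(F)(F)F` gives 1800 nM
compound 3 `O=C(/C=C/c1ccc(O)c(O)c1)NCc1ccc(C(F)(F)F)cc1` gives 1600 nM

Compound 2 at 1800 nM lies within the scatter of compound 3 at 1600 nM and far under compound 1 at 20000 nM on the same read-out. Compound 2 therefore belongs with compound 3 at the low end of these three numbers.

Compound 4 `COc1ccccc1CNC(=O)/C=C/c1ccc(O)c(O)c1` has not yet been measured in this assay and is the next point of interest. Its difference from compound 2 is methoxy in place of trifluoromethyl on an aromatic carbon and nothing else changes.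

Among the compounds with values here, one measured step bears on this change. The step of an 11-fold lower number from compound 1 to compound 2 (1.05 log units; beyond the scatter) is large and beyond the scatter, and it is methyl giving way to trifluoromethyl on an aromatic carbon. Read in reverse, it shows a much higher number once trifluoromethyl is lost. Within the data shown here, compound 4 loses trifluoromethyl as well, but no measured compound carries methoxy, so that step gives only a direction and a rough upper size. A rise is expected in this assay and it should probably be smaller than the measured step. The estimated step of a 3.3-fold higher number from compound 2 to compound 4 (0.52 log units; beyond the scatter) is a moderate rise beyond the scatter. The expected value for compound 4 is 6000 nM with an estimated range of 1800 nM to 20000 nM for the measurement.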

Compound 4, half-maximal inhibitory concentration: 7000 nM
For compound 4 the middle estimate is 1.2-fold (0.07 log units) below the measured one; measured number inside the range.
By their numbers in this assay, from the lowest: compounds 3 and 2 (each within the scatter of the next); then compound 4; then compound 1.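

In this assay this position now holds three groups, and each pair of them is separated beyond the scatter, so the earlier contrast between methyl and trifluoromethyl becomes a graded series. Replacing trifluoromethyl with methoxy gives a 3.9-fold higher number from compound 2 to compound 4 (0.59 log units; beyond the scatter), while replacing methyl with methoxy gives a 2.9-fold lower number from compound 1 to compound 4 (0.46 log units; beyond the scatter), so compound 4 keeps part of the gain seen in compound 2 and the read-out here does not simply split into trifluoromethyl against everything else. Nothing available accounts for this order of methyl, methoxy and trifluoromethyl.

From the compounds shown here alone, it remains open what an amine, a nitrile, a carboxylic acid or a longer chain such as ethoxy would give on this aromatic carbon, and so whether the number can fall further than in compound 2 with a group other than trifluoromethyl. Also open is whether the same order of the three groups holds where compound 3 carries its trifluoromethyl, since only that one group is shown there.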